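Swapping Fluoro for Methoxy on the Benzyl Amide

This account rests on a few compounds, and the source may have more. Where it says the series, first, only, none or still open, it means among the compounds named here.

Compound 1 `COc1ccc(CNC(=O)CC2c3ccccc3N=C(N(C)CCCCCN(C)C)N2c2ccc(-c3ccccc3)cc2)cc1`: 1380 nM
Compound 2 `Cc1ccc(CNC(=O)CC2c3ccccc3N=C(N3CCN(CCN(C)C)CC3)N2c2ccc(-c3ccccc3)cc2)cc1`: 1600 nM
Compound 3 `CN(C)CCN1CCN(C2=Nc3ccccc3C(CC(=O)NCc3ccc(F)cc3)N2c2ccc(-c3ccccc3)cc2)CC1`: 1600 nM

In a functional assay on A2780 cells (Homo sapiens) for cytotoxicity, read by MTT assay, with a stated time of 48 h (on this read-out lower numbers stand for stronger inhibition and higher numbers for weaker inhibition), compound 3 stands level with compound 2, and compound 1 lies within the scatter of both, so the three numbers are not distinguishable. Compound 4 `COc1ccc(CNC(=O)CC2c3ccccc3N=C(N3CCN(CCN(C)C)CC3)N2c2ccc(-c3ccccc3)cc2)cc1` arises from compound 3 by methoxy in place of fluoro on an aromatic carbon. Among the measured compounds shown here, one measured step touches the same position: no change at the digits printed from compound 2 to compound 3 (within the scatter), which left the number unchanged. Compound 1 carries the methoxy group on a different amine chain, and its value sits within the scatter of compound 3. Compound 4 is therefore expected to show no shift beyond the scatter, an expected step of a 1.1-fold lower number from compound 3 to compound 4 (0.03 log units; within the scatter). The estimate for compound 4 is 1500 nM, with an expected range from 700 nM to 3200 nM.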

Compound 4, half-maximal inhibitory concentration: 1440 nM
Estimate against measurement, compound 4: 1.0-fold (0.02 log units) above, within the range that was stated.
By their numbers in this assay, from the lowest: compounds 1, 4, 2 and 3 (each within the scatter of the next).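

Methoxy, fluoro and methyl on this aromatic carbon cannot be told apart in this assay, which shows a 1.1-fold lower number from compound 3 to compound 4 (0.05 log units; within the scatter) and a 1.1-fold lower number from compound 2 to compound 4 (0.05 log units; within the scatter) as the steps to the methoxy compound. With the 4-methoxybenzyl amide now held fixed, the amine chains can be compared directly: 4-(2-(dimethylamino)ethyl)piperazin-1-yl in place of (5-(dimethylamino)pentyl)(methyl)amino gives a 1.0-fold higher number from compound 1 to compound 4 (0.02 log units; within the scatter) in the same assay. Nothing available speaks to the reason for these results. Still open, as far as these compounds go, is whether an amine or a carboxylic acid on this aromatic carbon would stand apart from these three groups.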